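The source may hold more compounds than are shown below. What is called first, only, known or untested is meant among the compounds shown, and "the series" means these compounds.

Compound 1 `c1cc([C@H]2CC[C@]3(CC2)OOC2(O3)C3CC4CC(C3)CC2C4)ccc1OCCOC1CCNCC1` is built on a shared core that carries a chain ending in a saturated ring with a nitrogen. In an ADME assay on microsomes from liver (Homo sapiens) for metabolic stability, read by LC-MS, tested at 1 uM (a lower number here means slower removal, a higher number faster removal of the compound), compound 1 gives < 7 mL.min-1.g-1, which is a limit of the assay rather than a number. Compound 2 `CC(C)(N)CCOc1ccc([C@H]2CC[C@]3(CC2)OOC2(O3)C3CC4CC(C3)CC2C4)cc1` and compound 3 `c1cc([C@H]2CC[C@]3(CC2)OOC2(O3)C3CC4CC(C3)CC2C4)ccc1OCCC1CCNCC1` keep the same core and differ only in the tail of that chain. In this assay compound 2 gives < 7 mL.min-1.g-1, again a limit. In this assay compound 3 gives < 7 mL.min-1.g-1, also a limit. Because (the limit of < 7 mL.min-1.g-1 in this assay, at which 3 of the 3 values shown sit), none of the steps among these three can be sized: a step that the two limits leave unreadable from compound 1 to compound 2, a step that the two limits leave unreadable from compound 1 to compound 3 and a step that the two limits leave unreadable from compound 2 to compound 3.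

Compound 4 `NCCCCOc1ccc([C@H]2CC[C@]3(CC2)OOC2(O3)C3CC4CC(C3)CC2C4)cc1` is the next variation on the tail: 2-aminoethyl in place of (piperidin-4-yl)oxy on a saturated chain carbon, two bonds along the chain from an oxygen on an aromatic ring. The measured steps bear on it only in showing that each tail tried so far stayed at the limit, so no readable step in either direction is expected, a step that the limit leaves unreadable from compound 1 to compound 4. Compound 4 is therefore expected to give about 5 mL.min-1.g-1 in this assay, within a range of 2 mL.min-1.g-1 to 12 mL.min-1.g-1.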

Compound 4, intrinsic clearance in microsomes: < 7 mL.min-1.g-1
Compound 4: only a limit was reported; the forecaster's own chance of this, stated with the estimate: 70%; the middle value lies beyond the limit too.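

Compound 4 also returns a limit rather than a number in this assay, so its steps to compound 1, compound 2 and compound 3 cannot be sized: the limit of < 7 mL.min-1.g-1 in this assay, at which 4 of the 4 values shown sit. The compounds shown leave open whether these four tails differ at all in this assay.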